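The compounds below may be only part of what the source reports. "The series", "measured", "known", "first", "only" and "open" are said of these compounds alone.

This account follows a short series of compounds sharing one core, examined in an ADME assay on microsomes from liver (Homo sapiens) for metabolic stability, read by LC-MS, using NADPH, with a stated time of 45 min, tested at 0.5 uM; on this read-out higher numbers stand for fast clearance and lower numbers for slow clearance. Compound 1, `O=C(CCCSc1nc2cc(Cl)ccc2o1)N1CCCC1`, gives 3.4 mL/min/g in this assay. Its companion, compound 2, `O=C(CCSc1nc2cc(Cl)ccc2o1)N1CCCCC1`, gives 10.7 mL/min/g in this assay. Of these two numbers compound 1 holds the lower one, and the gap between the two lies beyond the usual scatter of repeated measurements, so compound 1 stands as the slower-cleared of the pair on the numbers in hand.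

The step considered here leads from compound 1 to compound 3, `O=C1CCCN1CCCSc1nc2cc(Cl)ccc2o1`. The structural change is 2-oxopyrrolidin-1-yl in place of (pyrrolidin-1-yl)carbonyl on a saturated chain carbon, three bonds along the chain from a sulfur. The group that leaves and the group that enters are of nearly the same size, each a five-membered non-aromatic ring with one hetero atom, each with one hydrogen-bond acceptor and no donor. Among the measured compounds shown here, nothing among the measured compounds records a comparable change, so the expectation rests on this closeness alone. The step from compound 1 to compound 3 in this assay is estimated at a 1.2-fold higher number from compound 1 to compound 3 (0.07 log units; within the scatter), which is expected to lie within the scatter rather than beyond it. Compound 3 is therefore expected to give about 4 mL/min/g in this assay, with a range from 1.5 mL/min/g to 10 mL/min/g.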

Compound 3, intrinsic clearance in a liver preparation (reported as CLH), per the amount of preparation that the assay uses: 4.8 mL/min/g
Beside the measured number, compound 3's estimate is 1.2-fold (0.08 log units) below it; low and high end bracket the measured number.
By their numbers in this assay, from the lowest: compounds 1 and 3 (each within the scatter of the next); then compound 2.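

In this assay, among the compounds shown here, 2-oxopyrrolidin-1-yl in place of (pyrrolidin-1-yl)carbonyl on a saturated chain carbon, three bonds along the chain from a sulfur, gives a 1.4-fold higher number from compound 1 to compound 3 (0.15 log units; within the scatter), the first step that differs in one place only. On this read-out the two groups cannot be told apart at this position, so the low number of compound 1 does not depend on the (pyrrolidin-1-yl)carbonyl group as such, and a chain end joined through the ring nitrogen serves as well as one joined through the carbonyl carbon. Nothing measured here speaks to the reason for this closeness.

Compound 2 differs from compound 1 in both the chain and the ring, so the compounds shown do not separate the contribution of either one to the gap between their numbers. Also open, on these data alone, is how this position would respond to a group of another kind, such as a carboxylic acid, a primary amine or a six-membered 2-oxopiperidin-1-yl ring, and whether the closeness of these two groups would hold on a shorter chain.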